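From Nitrile to Amide on a Shared Core

The source may report more compounds than this note shows. Statements on the series, on what has been measured and on what is new or still open speak of the compounds shown alone.

The three measured compounds share one core carrying either a cyano or a carbamoyl group. Compound 3 `C[C@H](Oc1cc2cc(C#N)ccc2nc1N)c1cc(F)ccc1-n1cccn1` gives 40 uL/min in an ADME assay on cells (Hepatocyte, Homo sapiens) for metabolic stability (on this read-out higher numbers stand for fast clearance and lower numbers for slow clearance), the highest of the three numbers at hand. Compound 2 `C[C@H](Oc1cc2cc(C(N)=O)ccc2nc1N)c1cc(F)c(F)cc1-n1cccn1` gives 14 uL/min in this assay, and compound 1 `C[C@H](Oc1cc2cc(C(N)=O)cc(F)c2nc1N)c1ncc(F)cc1-n1cccn1` gives 4 uL/min, each beyond the scatter below compound 3.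

Compound 4 `C[C@H](Oc1cc2cc(C(N)=O)ccc2nc1N)c1cc(F)ccc1-n1cccn1` has not yet been measured in this assay. It differs from compound 3 in one place: carbamoyl in place of cyano on an aromatic carbon. Among the compounds with values here, both carbamoyl compounds measured so far sit well below compound 3, so a step toward slower clearance is expected, not one within the scatter. The estimate for compound 4 is 18 uL/min, with a range from 7 uL/min to 40 uL/min, because compound 2 with the same carbamoyl group gives 14 uL/min in this assay. This estimate means an expected step of a 2.2-fold lower number from compound 3 to compound 4 (0.35 log units; beyond the scatter), whose exact size remains uncertain with only these three measured compounds to go on.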

Compound 4, intrinsic clearance in a liver preparation (reported as CLH), per the amount of preparation that the assay uses in the Hepatocyte assay: 13 uL/min
Compound 4: middle estimate off by 1.4-fold (0.14 log units), on the high side; low and high end bracket the measured number.
By their numbers in the Hepatocyte assay, from the lowest: compound 1; then compounds 4 and 2 (each within the scatter of the next); then compound 3.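

Within the data shown here, in the Hepatocyte assay, carbamoyl in place of cyano on an aromatic carbon gives a 3.1-fold lower number from compound 3 to compound 4 (0.49 log units; beyond the scatter), the first reading of this change on its own, since the earlier compounds differed from one another in more than one place. In the Hepatocyte assay, hydrogen in place of fluoro on an aromatic carbon gives a 1.1-fold lower number from compound 2 to compound 4 (0.03 log units; within the scatter), so the extra fluoro of compound 2 makes no difference that can be read. In a physicochemical assay for lipophilicity, using the shake flask method (a higher number here means a more lipophilic compound, a lower number a more polar compound), compound 3 gives 3.8 and compound 4 gives 3, so the same change also makes the compound less lipophilic, and the slower clearance goes with that fall: the measured distribution coefficient of compound 3, 3.8, and of compound 4, 3, a number 0.80 log units lower (beyond the scatter)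

A single pair cannot separate the effect of lower lipophilicity from that of the carbamoyl group itself. On these data alone, how a carboxylic acid or a methyl ester would behave at this position in the Hepatocyte assay remains open.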